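From cyclopropyl to dimethylamino on a sulfonyl sulfur

The source may report more compounds than this note shows. Statements on the series, on what has been measured and on what is new or still open speak of the compounds shown alone.

In an ADME assay on MDCKII-LE cells (Canis lupus familiaris) for permeability (a lower number here means that the compound crosses the layer more slowly, a higher number that the compound crosses the layer faster), compound 1 (`Cc1cnc(NC(=O)c2cc(Oc3ccc(C(=O)N(C)C)cc3)c3cn(C)nc3c2)cn1`) gives 14.6 10^-6 cm/s, and compound 2 (`Cc1cnc(NC(=O)c2cc(Oc3ccc(S(=O)(=O)C4CC4)cc3)c3cn(C)nc3c2)cn1`) gives 17.8 10^-6 cm/s. For the measured compounds named here, compound 2 therefore stands within the scatter of the only other measured compound. Compound 3 (`Cc1cnc(NC(=O)c2cc(Oc3ccc(S(=O)(=O)N(C)C)cc3)c3cn(C)nc3c2)cn1`) has dimethylamino in place of cyclopropyl on a sulfonyl sulfur, turning cyclopropylsulfonyl into dimethylsulfamoyl: dimethylamino in place of cyclopropyl on a sulfonyl sulfur. Going by the values given here, no measured step makes this exact exchange. Among the compounds with values here, the one measured step, a 1.2-fold higher number from compound 1 to compound 2 (0.09 log units; within the scatter), puts cyclopropylsulfonyl in place of dimethylcarbamoyl on an aromatic carbon, so it bears on the new change only indirectly. That single step stays within the scatter, and it gives no reason to expect a larger move here. In this assay the expected change is therefore none beyond the scatter, with an estimated step of a 1.1-fold lower number from compound 2 to compound 3 (0.05 log units; within the scatter). Compound 3 is expected to give 16 10^-6 cm/s, with an estimated range from 9 10^-6 cm/s to 27 10^-6 cm/s.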

Compound 3, apparent permeability in the MDCKII-LE assay: 13.6 10^-6 cm/s
For compound 3 the middle estimate is 1.2-fold (0.07 log units) above the measured one; measured number inside the range.
By their numbers in the MDCKII-LE assay, from the lowest: compounds 3, 1 and 2 (each within the scatter of the next).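

In the MDCKII-LE assay, dimethylamino in place of cyclopropyl on a sulfonyl sulfur gives a 1.3-fold lower number from compound 2 to compound 3 (0.12 log units; within the scatter) and dimethylsulfamoyl in place of dimethylcarbamoyl gives a 1.1-fold lower number from compound 1 to compound 3 (0.03 log units; within the scatter) so all three groups at this position now read within the scatter of one another. In a physicochemical assay for solubility, measured as kinetic solubility (on this read-out lower numbers stand for lower solubility and higher numbers for higher solubility), the exchange on the sulfonyl sulfur gives a 1.8-fold higher number from compound 2 to compound 3 (0.26 log units; within the scatter) and so this change, too, stays within the scatter in the physicochemical assay, where compound 2 gives 73000 nM and compound 3 gives 134000 nM as a pair. Nothing available accounts for these readings.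

As far as these compounds go, whether morpholine or a longer chain on the sulfonyl sulfur would move either read-out beyond the scatter remains open. So does whether a carboxylic acid on the aromatic carbon in place of the sulfonyl group would do so.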